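The source may hold more compounds than are shown below. What is called first, only, known or untested is meant among the compounds shown, and "the series" means these compounds.

Measured so far in an ADME assay on CCRF-HSB-2 cells (Homo sapiens) for cytotoxicity, with a stated time of 7 days; a lower number here means that less compound is tolerated, a higher number that more compound is tolerated:
Compound 1, `CCCCNc1nc(N)nc2c1ncn2/C=C1/CC1(CO)CO`, gives > 20000 nM, which is a limit of the assay.
Compound 2, `Nc1nc(N2CCCC2)c2ncn(/C=C3/CC3(CO)CO)c2n1`, gives > 20000 nM, which is also a limit of the assay.
Compound 3, `CCCCCCCCSc1nc(N)nc2c1ncn2/C=C1/CC1(CO)CO`, gives 60000 nM.

Among the measured compounds shown here, compound 3 stands as the only compound with an actual number in this assay; the other two sit at the limit of > 20000 nM in this assay, at which 2 of the 3 values shown sit. The steps among the measured compounds, a step that the two limits leave unreadable from compound 1 to compound 2, a step that the limit leaves unreadable from compound 1 to compound 3 and a step that the limit leaves unreadable from compound 2 to compound 3, cannot be read in size, since each of them rests on at least one limit. Compound 4, `Nc1nc(SCc2ccccc2)c2ncn(/C=C3/CC3(CO)CO)c2n1`, has not yet been measured. It differs from compound 3 in a single place: phenyl in place of heptyl on a saturated chain carbon bound to a sulfur. For the measured compounds named here, none of the measured steps changes the group on the sulfur in this manner, so they offer no sized precedent; what they do show is that all three measured compounds are tolerated at high concentrations in this assay. With no readable step to build on, compound 4 is expected to stay close to compound 3, so that the estimated step is a 1.2-fold lower number from compound 3 to compound 4 (0.08 log units; within the scatter). The estimate for compound 4 in this assay is 50000 nM, with a range from 15000 nM to 200000 nM.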

Compound 4, half-maximal cytotoxic concentration: > 100000 nM
Compound 4 was reported as a limit; the forecaster's own chance of this, stated with the estimate: 40%; middle value at least 2.0-fold (0.30 log units) from the limit.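

In this assay, compound 4 gives > 100000 nM, which is a limit of the assay, and it stands alone at that limit: the limit of > 100000 nM in this assay, at which 1 of the 4 values shown sits.

Phenyl in place of heptyl on a saturated chain carbon bound to a sulfur, which also reads as octylsulfanyl to benzylsulfanyl, gives an at least 1.6-fold higher number from compound 3 to compound 4 (0.22 log units; that floor lies within the scatter), so this is the first change of the group on the sulfur with a readable floor, and that floor does not by itself establish a change beyond the usual scatter. Among the compounds shown here, the result does show that a ring-bearing benzyl group at this position brings no lower number than the straight octyl chain, whereas the earlier compounds showed nothing about the group on the sulfur; the steps from compound 1 and from compound 2 to compound 4 cannot be read.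

From the compounds shown here alone, the full size of the step to compound 4 stays open, since only a floor is available. Also open, going by these compounds, is how the number would respond to a short chain such as ethyl on the sulfur, or to a benzyl group carrying an amine or a carboxylic acid on its ring.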